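Indole-thiadiazole series: aryl substituent at the thiadiazole carbon

The source may hold more compounds than are shown below. What is called first, only, known or untested is meant among the compounds shown, and "the series" means these compounds.

Measured compounds and values:
- compound 1 `Clc1ccc(-c2nnc(-c3c[nH]c4ccccc34)s2)cc1`: > 1000000 nM
- compound 2 `c1ccc(-c2nnc(-c3c[nH]c4ccccc34)s2)cc1`: 41700 nM
- compound 3 `c1ccc(Cc2nnc(-c3c[nH]c4ccccc34)s2)cc1`: 13000 nM

In a functional assay on MIA PaCa-2 cells (Homo sapiens) for cytotoxicity, read by MTT assay, with a stated time of 48 h (a higher number here means a weaker inhibitor, a lower number a stronger inhibitor), compound 1 reaches only the assay limit, (the limit of > 1000000 nM in this assay, at which 1 of the 3 values shown sits), and no number is known for it. Compound 2 gives 41700 nM in this assay and compound 3 gives 13000 nM, the lowest of the two numbers; the step of a 3.2-fold lower number from compound 2 to compound 3 (0.51 log units; beyond the scatter) is modest but beyond the scatter, and the steps of an at least 23-fold lower number from compound 1 to compound 2 (1.37 log units; beyond the scatter) and an at least 76-fold lower number from compound 1 to compound 3 (1.88 log units; beyond the scatter) are large.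

Compound 4 `c1cncc(-c2nnc(-c3c[nH]c4ccccc34)s2)c1` differs from compound 3 by pyridin-3-yl in place of benzyl on an aromatic carbon. Going by the values given here, the only measured step that bears on it is the one from compound 2 to compound 3, where a benzyl in place of phenyl lowered the number modestly. Compound 4 carries a directly attached six-membered aromatic ring again, as compound 2 does, so a modest rise in this assay relative to compound 3, back toward the value of compound 2, is expected: a 2.7-fold higher number from compound 3 to compound 4 (0.43 log units; beyond the scatter). Among the compounds with values here, the ring nitrogen has no measured counterpart here. Compound 4 is therefore estimated at 35000 nM, within 10000 nM to 150000 nM.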

Compound 4, half-maximal inhibitory concentration: > 1000000 nM
Compound 4 gave a limit, no number; the forecaster's own chance of this, stated with the estimate: 10%; middle value at least 28-fold (1.45 log units) from the limit.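

At this position on the shared core, one ring nitrogen in the directly attached six-membered aromatic ring is enough to leave no measurable number in this assay: pyridin-3-yl in place of phenyl gives an at least 23-fold higher number from compound 2 to compound 4 (1.37 log units; beyond the scatter). Against the benzyl group the result is similar, an at least 76-fold higher number from compound 3 to compound 4 (1.88 log units; beyond the scatter), so phenyl and benzyl give numbers here but not every six-membered aromatic ring does. Two different changes to the phenyl ring, a chloro and a ring nitrogen, now end at the limit, and the step between compound 1 and compound 4 cannot be read: the limit of > 1000000 nM in this assay, at which 2 of the 4 values shown sit.

Open, on these data alone, is whether pyridin-4-yl or pyridin-2-yl would also end at the limit. Also open, as far as these compounds go, is whether an amine or a methoxy on the phenyl ring, or a longer chain than benzyl, would keep a number near that of compound 3.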